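From compound 2 to compound 4: adding diethylamino

The source may report more compounds than this note shows. Statements on the series, on what has been measured and on what is new or still open speak of the compounds shown alone.

Compound 1 `CN(C(=O)CNC(=O)CN1CCCCC1)c1ccc(Cl)cc1C(=O)c1ccccc1Cl`: 7.5 mg/kg
Compound 2 `CC(=O)NCC(=O)N(C)c1ccc(Cl)cc1C(=O)c1ccccc1Cl`: 2.3 mg/kg
Compound 3 `CCCCCCC(=O)NCC(=O)N(C)c1ccc(Cl)cc1C(=O)c1ccccc1Cl`: 1.9 mg/kg

These numbers come from a functional assay on the whole organism for antagonist activity, with Mus musculus as the target; on this read-out higher numbers stand for an effect only at larger amounts of compound and lower numbers for an effect already at smaller amounts. Compound 2 lies within the scatter of compound 3 and well under compound 1. Compound 4 `CCN(CC)CC(=O)NCC(=O)N(C)c1ccc(Cl)cc1C(=O)c1ccccc1Cl` differs from compound 2 by diethylamino in place of hydrogen on a saturated chain carbon bound to a carbonyl carbon. The nearest measured precedent is piperidin-1-yl in compound 1, which shows a 3.3-fold lower number from compound 1 to compound 2 (0.51 log units; beyond the scatter). Read in reverse, that modest step points upward. Pentyl in compound 3 gave only a 1.2-fold lower number from compound 2 to compound 3 (0.08 log units; within the scatter), but it is no amino group. The expected step is therefore a 2.6-fold higher number from compound 2 to compound 4 (0.42 log units; beyond the scatter). Compound 4 is estimated at 6 mg/kg, with an expected range of 2.5 mg/kg to 14 mg/kg.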

Compound 4, dose for half-maximal effect: 2.2 mg/kg
For compound 4 the middle estimate is 2.7-fold (0.44 log units) above the measured one; measured number outside the range, below it.
By their numbers in this assay, from the lowest: compounds 3, 4 and 2 (each within the scatter of the next); then compound 1.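

At this saturated chain carbon bound to a carbonyl carbon, diethylamino cannot be told apart from hydrogen, with a 1.0-fold lower number from compound 2 to compound 4 (0.02 log units; within the scatter), or from pentyl, with a 1.2-fold higher number from compound 3 to compound 4 (0.06 log units; within the scatter). An amino group at this carbon is therefore not enough to give the high number of compound 1, which remains apart from the other compounds, with a 3.4-fold lower number from compound 1 to compound 4 (0.53 log units; beyond the scatter). Nothing available explains the gap between piperidin-1-yl and diethylamino. From the compounds shown here alone, whether pyrrolidin-1-yl or morpholin-4-yl would fall with compound 1 or with compound 4 stays open, as does how a carboxylic acid would read at this carbon.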